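Allyl to Benzyl and Cytotoxicity across Three Compounds

The source may report more compounds than this note shows. Statements on the series, on what has been measured and on what is new or still open speak of the compounds shown alone.

Measured compounds:
compound 1, `C=CCN1[C@H](c2ccc([N+](=O)[O-])cc2)C(C(=O)OC)C(=O)C(C(=O)OC)[C@@H]1c1ccc([N+](=O)[O-])cc1`: 50.3 uM
compound 2, `COC(=O)C1C(=O)C(C(=O)OC)[C@H](c2ccccn2)N(Cc2ccccc2)[C@@H]1c1ccccn1`: 34 uM
compound 3, `C=CCN1[C@H](c2ccccn2)C(C(=O)OC)C(=O)C(C(=O)OC)[C@@H]1c1ccccn1`: a limit, > 100 uM

In an ADME assay on J774.1 cells (Mus musculus) for cytotoxicity, with a stated time of 48 h (on this read-out higher numbers stand for an effect only at larger amounts of compound and lower numbers for an effect already at smaller amounts), compound 1 gives 50.3 uM and compound 2 gives 34 uM, two numbers that lie within the scatter of each other. For compound 3 this assay reports only a limit, > 100 uM, and the value sits at the limit of > 100 uM in this assay, at which 1 of the 3 values shown sits.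

One change is made twice in this set. From compound 3 to compound 2 it is phenyl in place of vinyl on a saturated chain carbon bound to an amine nitrogen in a ring, and it gave an at least 2.9-fold lower number from compound 3 to compound 2 (0.46 log units; beyond the scatter). The same change, (phenyl in place of vinyl on a saturated chain carbon bound to an amine nitrogen in a ring), leads from compound 1 to compound 4, whose structure is `COC(=O)C1C(=O)C(C(=O)OC)[C@H](c2ccc([N+](=O)[O-])cc2)N(Cc2ccccc2)[C@@H]1c1ccc([N+](=O)[O-])cc1`. The place is the same in both pairs, so the change is the same. How the core of compound 1 differs from the core of compound 3 is not broken down here.

For compound 4 a step in this assay of a 2.8-fold lower number from compound 1 to compound 4 (0.45 log units; beyond the scatter) is expected, resting on the step of an at least 2.9-fold lower number from compound 3 to compound 2 (0.46 log units; beyond the scatter) seen for the same change, while noting that compound 1 starts from a measured number, 50.3 uM, rather than a limit. Compound 4 is therefore estimated at 18 uM, between 7 uM and 50 uM.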

Compound 4, concentration for half-maximal effect: 18.4 uM
Compound 4: middle estimate off by 1.0-fold (0.01 log units), on the low side; low and high end bracket the measured number.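

In this assay, the change from allyl to benzyl on the core of compound 1 gives a 2.7-fold lower number from compound 1 to compound 4 (0.44 log units; beyond the scatter) and so points the same way as it did on the core of compound 3, which suggests that within these two pairs the change carries from one core to the other. Set side by side, the two results read: the same change on two cores in this assay, an at least 2.9-fold lower number (0.46 log units; beyond the scatter) from compound 3 to compound 2 and a 2.7-fold lower number (0.44 log units; beyond the scatter) from compound 1 to compound 4; the limit leaves it open whether they differ. This does not fix the size of the step on the core of compound 3 or show that the two steps are equal, as the value of compound 3 is a limit and not a number: the limit of > 100 uM in this assay, at which 1 of the 4 values shown sits.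

With only two cores, the compounds shown leave open whether the same change would hold on any further core. They also leave open how this cytotoxicity read-out would respond if the benzyl group gave way to a longer chain bearing a phenyl ring, or if an amine or a carboxylic acid were carried on that group.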